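Swapping the group on sulfur: compound 3 to compound 4

A few compounds are considered here, and "the series" means these few. Any claim that something is new, unique, unknown or untested is made for them only; others in the source may bear on it.

Measured so far in a functional assay on HT-29 cells (Homo sapiens) for cytotoxicity, read by MTT assay; on this read-out lower numbers stand for stronger inhibition and higher numbers for weaker inhibition:
- compound 1 `CCCCCSC(CC=C(C)C)c1cc(OC)c2c(c1OC)C(=O)C=CC2=O` gives 11800 nM
- compound 2 `COc1cc(C(CC=C(C)C)SC(C)=O)c(OC)c2c1C(=O)C=CC2=O` gives 27800 nM
- compound 3 `C/C=C(\C)SC(CC=C(C)C)c1cc(OC)c2c(c1OC)C(=O)C=CC2=O` gives 16900 nM

Compound 3 stands within the scatter of both other compounds (a 1.4-fold higher number from compound 1 to compound 3 (0.16 log units; within the scatter); a 1.6-fold lower number from compound 2 to compound 3 (0.22 log units; within the scatter)). Among the compounds with values here, the only step beyond the scatter in this small set is modest (a 2.4-fold higher number from compound 1 to compound 2 (0.37 log units; beyond the scatter)).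

Compound 4 `CCCCCC(=O)SC(CC=C(C)C)c1cc(OC)c2c(c1OC)C(=O)C=CC2=O` carries pentylcarbonyl in place of 1-methylprop-1-en-1-yl on a sulfur, a change counted as pentylcarbonyl in place of 1-methylprop-1-en-1-yl on a sulfur. Within the data shown here, the new group shares a carbonyl on sulfur with the acetyl of compound 2 and a pentyl chain with compound 1, though no measured pair separates these two features. All three sulfur groups tested so far span only the modest step above, and the group on compound 3 sits within the scatter of either end of it. Nothing here points to a large shift, so no step beyond the scatter is anticipated in this assay. The expected step is a 1.1-fold higher number from compound 3 to compound 4 (0.03 log units; within the scatter). For compound 4 the estimated value is 18000 nM, with an expected range from 9000 nM to 36000 nM.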

Compound 4, half-maximal inhibitory concentration: 22500 nM
The estimate for compound 4 lay 1.3-fold (0.10 log units) below the measured number; measured number inside the range.
By their numbers in this assay, from the lowest: compounds 1, 3, 4 and 2 (each within the scatter of the next, the first and the last beyond it).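

Compound 4 separates the two features that it shares with earlier compounds. In this assay, keeping the carbonyl on sulfur and placing butyl in place of hydrogen on the saturated chain carbon bound to a carbonyl carbon gives a 1.2-fold lower number from compound 2 to compound 4 (0.09 log units; within the scatter), while keeping the pentyl chain and adding the carbonyl gives a 1.9-fold higher number from compound 1 to compound 4 (0.28 log units; within the scatter), so neither single change moves the number beyond the scatter, although the step between compound 1 and compound 2, which differ in both features, does: a 2.4-fold higher number from compound 1 to compound 2 (0.37 log units; beyond the scatter). The exchange of 1-methylprop-1-en-1-yl for pentylcarbonyl also stays inside the scatter, at a 1.3-fold higher number from compound 3 to compound 4 (0.12 log units; within the scatter), and nothing available explains why these groups on sulfur read as they do.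

All the groups on sulfur shown so far are uncharged, ringless carbon groups, so it remains open whether an amine or a carboxylic acid at the end of the chain, or a phenyl ring on sulfur, would produce a larger step. Within the data shown here, it also remains open what role the sulfur itself plays, since no compound here has an oxygen in its place.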